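The compounds below may be only part of what the source reports. "The series", "measured", "known", "first", "only" and "open" are said of these compounds alone.

Compound 3 `CCOc1ccc(-c2cccc(C(=O)OCCOCCOC)c2)cc1` is one of three esters sharing a core in an assay on COS-7 cells for inhibition of patatin-like phospholipase domain-containing protein 2 (Mus musculus); on this read-out higher numbers stand for weaker inhibition and lower numbers for stronger inhibition. Compound 1 `CCOC(=O)c1cccc(-c2ccc(OCC)cc2)c1` gives 50000 nM. Compound 2 `CCCCCCOC(=O)c1cccc(-c2ccc(OCC)cc2)c1` reaches only the limit > 200000 nM. Compound 3 likewise reaches only the limit > 200000 nM, so it sits at the limit of > 200000 nM in this assay, at which 2 of the 3 values shown sit, together with compound 2. Compound 4 `CCOc1ccc(-c2cccc(C(=O)N3CCCC3)c2)cc1` differs by pyrrolidin-1-yl in place of 2-(2-methoxyethoxy)ethoxy on a carbonyl carbon. For the measured compounds named here, no measured step exchanges an ester for an amide; the steps that touch the same region, an at least 4.0-fold higher number from compound 1 to compound 2 (0.60 log units; beyond the scatter) and an at least 4.0-fold higher number from compound 1 to compound 3 (0.60 log units; beyond the scatter), both weakened inhibition, while a step that the two limits leave unreadable from compound 2 to compound 3. An expectation for compound 4 therefore rests on weak ground, and the step of an at least 2.0-fold lower number from compound 3 to compound 4 (0.30 log units; that floor lies within the scatter) is estimated only loosely. Compound 4 is expected to give about 100000 nM, between 20000 nM and 400000 nM in this assay.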

Compound 4, half-maximal inhibitory concentration: 160000 nM
The estimate for compound 4 lay 1.6-fold (0.20 log units) below the measured number; measured number inside the range.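

Pyrrolidin-1-yl in place of ethoxy on the carbonyl carbon gives a 3.2-fold higher number from compound 1 to compound 4 (0.51 log units; beyond the scatter), so at this position an amide reads weaker than the ethoxy ester. Against the hexyloxy and 2-(2-methoxyethoxy)ethoxy esters, the same position shows an at least 1.2-fold lower number from compound 2 to compound 4 (0.09 log units; that floor lies within the scatter) and an at least 1.2-fold lower number from compound 3 to compound 4 (0.09 log units; that floor lies within the scatter); both floors lie within the scatter, so no gain over either ester is established.

Going by these compounds, it remains open whether a carboxylic acid or a dimethylamino group on this carbonyl carbon would give a lower number than compound 1 at 50000 nM.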